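The source may report more compounds than this note shows. Statements on the series, on what has been measured and on what is new or still open speak of the compounds shown alone.

Measured compounds:
compound 3, `CN1CCN(c2ccc(Nc3nc(-c4cccc(NC(=O)c5ccc(C(F)(F)F)cc5)c4)sc3C(N)=O)cc2)CC1`: 3210 nM
compound 1, `CCOC(=O)c1sc(-c2cccc(NC(=O)c3ccc(C(F)(F)F)cc3)c2)nc1Nc1ccc(N2CCN(C)CC2)cc1`: "not determined" (no result reported)
compound 2, `CCOC(=O)c1sc(-c2cccc(NC(=O)c3ccc(Cl)cc3)c2)nc1Nc1ccc(N2CCN(C)CC2)cc1`: "not determined" (no result reported)

In a functional assay on Raji cells (Homo sapiens) for antiproliferative activity, read by CCK-8 assay, with a stated time of 72 h (on this read-out higher numbers stand for weaker inhibition and lower numbers for stronger inhibition), compound 3 gives 3210 nM. Going by the values given here, compounds 1 and 2 have no result in this assay, so compound 3 stands alone with the only number among the three; it cannot be set above or below either of them, and no step between measured compounds exists.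

Compound 4, `CN1CCN(c2ccc(Nc3nc(-c4cccc(NC(=O)c5ccco5)c4)sc3C(N)=O)cc2)CC1`, is the next entry due in this assay. It differs from compound 3 in one place: furan-2-yl in place of 4-(trifluoromethyl)phenyl on a carbonyl carbon. Among the compounds with values here, since the series holds no measured step, the size of this change is not anchored by any earlier pair. Within the data shown here, the expectation is still a shift beyond the scatter toward weaker inhibition, as a smaller fragment replaces the one present in compound 3, whose value of 3210 nM already sits in the micromolar range. In this assay the expected step is a 2.3-fold higher number from compound 3 to compound 4 (0.37 log units; beyond the scatter). Compound 4 is therefore estimated at 7500 nM in this assay. For compound 4 the expected range runs from 2500 nM to 25000 nM, with some chance that only an upper limit is reported.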

Compound 4, half-maximal inhibitory concentration: 37400 nM
Compound 4: the middle estimate sits 5.0-fold (0.70 log units) below what was measured; measured number above the stated range.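

Going by these compounds alone, the acyl group on the amide nitrogen is the first position with a measured step: in this assay, furan-2-yl in place of 4-(trifluoromethyl)phenyl on a carbonyl carbon gives a 12-fold higher number from compound 3 to compound 4 (1.07 log units; beyond the scatter). Activity at this position therefore depends strongly on the group carried there, and in this one pair the smaller furan-2-yl goes with the weaker inhibition. No measurement at hand bears on the reason for this step.

The exchange changes several things at once: ring size, the hetero atom, the trifluoromethyl group and the heavy-atom count, so compound 3 and compound 4 alone cannot show which of these carries the step. Open questions are how an unsubstituted phenyl or a thiophen-2-yl on the same carbonyl would read, and whether the step would keep its size with a different group elsewhere on the shared core.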